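Thioether benzamides: ethyl for methyl on the phenyl

The source may hold more compounds than are shown below. What is called first, only, known or untested is meant among the compounds shown, and "the series" means these compounds.

Measured so far in a functional assay on A549 cells (Homo sapiens) for inhibition, read by CCK-8 assay, with a stated time of 72 h, tested at 8 uM; on this read-out lower numbers stand for less inhibition of growth and higher numbers for more inhibition of growth at the one concentration tested:
- compound 1 `Nc1ccccc1NC(=O)c1ccc(CSc2nccc(C(F)(F)F)n2)cc1`: 95.1%
- compound 2 `Nc1ccccc1NC(=O)/C=C/c1ccc(CSc2ccc(F)cc2)cc1`: 59.1%
- compound 3 `Cc1ccc(SCc2ccc(C(=O)Nc3ccccc3N)cc2)cc1`: 78.3%

Compound 3 sits second of the three numbers. Its nearest neighbour is compound 1, whose number lies higher by more than the scatter, and its furthest is compound 2, whose number lies lower by more than the scatter.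

Compound 4 `CCc1ccc(SCc2ccc(C(=O)Nc3ccccc3N)cc2)cc1` is not yet measured. It differs from compound 3 by methyl in place of hydrogen on a saturated chain carbon bound to an aromatic carbon, which reads, one bond further out, as methyl to ethyl on the 4-methylphenyl.

Among the measured compounds shown here, no measured pair shows the effect of this change. Because compound 3 gives 78.3% in this assay and the change adds only one carbon, the step of a number 0.3 percentage points lower from compound 3 to compound 4 (within the scatter) is expected to stay within the scatter, in no clear direction. Compound 4 is therefore expected to give about 78%, within 62% to 92%.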

Compound 4, percent growth inhibition at one concentration: 91.4%
Beside the measured number, compound 4's estimate is 13.4 percentage points below it, within the range that was stated.
By their numbers in this assay, from the lowest: compound 2; then compound 3; then compounds 4 and 1 (each within the scatter of the next).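

In this assay, among the compounds shown here, the change from methyl to ethyl on the 4-methylphenyl gives a number 13.1 percentage points higher from compound 3 to compound 4 (beyond the scatter) and is the first step that can be read in one place. This position therefore responds to a single added carbon, and the step is modest. Nothing available explains the step.
On these data alone, whether a longer chain such as propyl, or an amine at this place, would go further remains open. So does whether the same change would act alike on the core of compound 2.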